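The source may report more compounds than this note shows. Statements on the series, on what has been measured and on what is new or still open speak of the compounds shown alone.

Working notes on the series. Going by the values given here, compound 2 `CCOC(=O)c1c(C)nc(-c2cccc(C#N)c2)n1C` gives 22100 nM in a functional assay on a cell-free system (plasma, Oryctolagus cuniculus) for inhibition, with stated times of 5 min, 1 min and 6 min (a lower number here means a stronger inhibitor, a higher number a weaker inhibitor), the highest of the three numbers measured so far. Compound 1 `CCOC(=O)c1c(C)nc(-c2cccc(C#N)c2)n1OC` gives 9130 nM in this assay, and compound 3 `CCOC(=O)COn1c(-c2cccc(C#N)c2)nc(C)c1C(=O)OCC` gives 6800 nM in this assay. The step to compound 4 `CCOC(=O)c1c(C)nc(-c2cccc(C#N)c2)n1OCc1ccc(Cl)cc1` is (4-chlorobenzyl)oxy in place of methyl on an aromatic nitrogen, an oxygen-linked group again taking the place of the methyl on the aromatic nitrogen. Among the compounds with values here, two measured steps bear on it: a 2.4-fold higher number from compound 1 to compound 2 (0.38 log units; beyond the scatter) and a 3.3-fold lower number from compound 2 to compound 3 (0.51 log units; beyond the scatter); in both, the methyl on that nitrogen carries the higher number and the oxygen-linked group the lower one. A modest lowering is therefore expected for compound 4. Compound 4 is expected to give 5500 nM in this assay, between 1800 nM and 16000 nM, which would mean a 4.0-fold lower number from compound 2 to compound 4 (0.60 log units; beyond the scatter).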

Compound 4, half-maximal inhibitory concentration: 6830 nM
For compound 4 the middle estimate is 1.2-fold (0.09 log units) below the measured one, within the range that was stated.
By their numbers in this assay, from the lowest: compounds 3, 4 and 1 (each within the scatter of the next); then compound 2.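

On the aromatic nitrogen, (4-chlorobenzyl)oxy in place of methyl gives a 3.2-fold lower number from compound 2 to compound 4 (0.51 log units; beyond the scatter), so a third oxygen-linked group now stands apart from the methyl of compound 2. On the saturated chain carbon bound to the oxygen, the added 4-chlorophenyl changes nothing that can be read in this assay: a 1.3-fold lower number from compound 1 to compound 4 (0.13 log units; within the scatter), and a 1.0-fold higher number from compound 3 to compound 4 (0.00 log units; within the scatter). Nothing available accounts for this flat response. From the compounds shown here alone, whether an amine or a carboxylic acid on that carbon, or a longer chain on the oxygen, would separate from these values stays open.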